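The compounds below may be only part of what the source reports. "The series", "measured", "known", "first", "only" and "open" are said of these compounds alone.

Measured in an ADME assay on CEM-SS cells (Homo sapiens) for cytotoxicity, read by XTT assay, with a stated time of 6 days; on this read-out lower numbers stand for higher toxicity in this test and higher numbers for lower toxicity in this test:
- compound 1 `CCCC(=O)OCSc1ccccc1C(=O)NC1(C(N)=O)CCCC1`: > 100 uM
- compound 2 `CCCC(=O)OCSc1ccccc1C(=O)NCCCCCCC(N)=O`: 10.4 uM
- compound 3 `CCCC(=O)OCSc1ccccc1C(=O)NCC(=O)NCc1ccccc1`: 29.3 uM

The entry for compound 1 is a limit of the assay, not a number. Of the two numeric values, the higher belongs to compound 3, and the gap down to compound 2 lies beyond the scatter.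

Compound 4 `CCCC(=O)OCSc1ccccc1C(=O)NCC(=O)NCC(N)=O` carries carbamoyl in place of phenyl on a saturated chain carbon bound to an amide-type nitrogen.

Compound 1 also carries a carbamoyl and sits at its limit of > 100 uM. Compound 2 carries one too, yet gives 10.4 uM, so the direction is uncertain.

A modest rise in this assay is expected, with the expected step of a 1.5-fold higher number from compound 3 to compound 4 (0.19 log units; within the scatter). The estimate for compound 4 is 45 uM, with an expected range of 15 uM to 100 uM.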

Compound 4, half-maximal toxic concentration: > 100 uM
Compound 4 ended at the assay's limit; the forecaster's own chance of this, stated with the estimate: 30%; middle value at least 2.2-fold (0.34 log units) away from the limit.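

Compound 4 sits at a limit of the assay, not at a number: the limit of > 100 uM in this assay, at which 2 of the 4 values shown sit. In this assay, carbamoyl in place of phenyl on a saturated chain carbon bound to an amide-type nitrogen gives an at least 3.4-fold higher number from compound 3 to compound 4 (0.53 log units; beyond the scatter), which settles the direction of this change at this position. A carbamoyl alone does not fix the read-out, as an at least 9.6-fold higher number from compound 2 to compound 4 (0.98 log units; beyond the scatter) shows, and the step between compound 1 and compound 4 cannot be read. Still open, from the compounds shown here alone, is how far past the limit compound 4 lies. Also open, going by these compounds, is whether a carboxylic acid or an amine in place of the carbamoyl would give the same reading.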